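The source may hold more compounds than are shown below. What is called first, only, known or untested is meant among the compounds shown, and "the series" means these compounds.

Compound 1 `CCn1c(=O)n(C2OC(CO)[C@@H](O)[C@H]2O)c2nc(N)nc(O)c21` was tested in a functional assay on the whole organism with Mus musculus as the target (a higher number here means a larger maximal response, a lower number a smaller maximal response), where compound 1 gives 82%. Two other compounds share its core. Compound 2 `C=CCn1c(=O)n(C2C=CC(CO)O2)c2nc(N)nc(O)c21` reaches 84% in this assay, a number that sits within the usual scatter of compound 1, so the two cannot be told apart. Compound 3 `C=CCn1c(=S)n(C2OC(COCc3ccccc3)[C@H]3OC(C)(C)O[C@@H]23)c2nc(N)nc(O)c21` gives 0% in this assay, far beneath compound 1 and well beyond the scatter. Compound 1 thus stands together with compound 2 at the upper end of the three numbers, with compound 3 far below both.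

Compound 4 `Nc1nc(O)c2c(n1)n(C1OC(CO)[C@@H](O)[C@H]1O)c(=O)n2Cc1ccc(Cl)c(Cl)c1` has not yet been measured in this assay. It differs from compound 1 in one place: 3,4-dichlorophenyl in place of methyl on a saturated chain carbon bound to an aromatic nitrogen. For the measured compounds named here, no measured pair shows this change, and compound 3 differs from compound 1 in several places at once, so its low number cannot be tied to any single group. The step from compound 1 to compound 4 is therefore expected to be downward, of size a number 32 percentage points lower from compound 1 to compound 4 (beyond the scatter), but with wide uncertainty. Compound 4 is expected to give 50% in this assay, between 5% and 90%.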

Compound 4, largest response reached (reported as maximal response), in percent of the reference or control that the assay uses: 0%
For compound 4 the middle estimate is 50 percentage points above the measured one; measured number outside the range, below it.
By their numbers in this assay, from the lowest: compounds 3 and 4 (each within the scatter of the next); then compounds 1 and 2 (each within the scatter of the next).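

In this assay the change of methyl to 3,4-dichlorophenyl on a saturated chain carbon bound to an aromatic nitrogen comes out as a number 82 percentage points lower from compound 1 to compound 4 (beyond the scatter), with the rest of compound 1 unchanged. For the compounds shown here, this ties a large loss of response to one place for the first time, which compound 3, differing in several places at once, could not do. The position therefore does not tolerate every group: ethyl goes with a high response and 3,4-dichlorobenzyl with none, though nothing at hand explains this difference.

Going by these compounds, it stays open whether the loss goes with the aromatic ring itself or with its two chlorines, which plain benzyl would help to separate. On these data alone, it also stays open how a longer chain such as butyl, or an amine at the end of the chain, would behave at this position.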